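The source may report more compounds than this note shows. Statements on the series, on what has been measured and on what is new or still open speak of the compounds shown alone.

Two compounds share one core, a cyclic ketone carrying two arylidene arms, one of them a nitrophenyl. Compound 1 `COc1cc(/C=C2\CCC/C(=C\c3ccccc3[N+](=O)[O-])C2=O)cc(OC)c1OC` carries a trimethoxyphenyl on the other arm and, in a functional assay on CCRF-CEM cells (Homo sapiens) for cytotoxicity, with a stated time of 72 h (a lower number here means a stronger inhibitor, a higher number a weaker inhibitor), compound 1 gives 402 nM. Compound 2 `CN(C)c1ccc(/C=C2\CCC/C(=C\c3ccccc3[N+](=O)[O-])C2=O)cc1` carries a dimethylaminophenyl instead, and in this assay compound 2 gives 168000 nM. That is the higher of the two numbers by a wide margin, well beyond the usual scatter, so compound 2 is the weaker of the pair.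

Compound 3 `Cc1ccc(/C=C2\CCC/C(=C\c3ccccc3[N+](=O)[O-])C2=O)cc1` is reached from compound 2 by a single change, methyl in place of dimethylamino on an aromatic carbon. For the measured compounds named here, no measured pair shows this exact change, so the expectation rests on the two numbers alone. A sizeable move toward stronger inhibition is expected from compound 2 to compound 3, an 8.4-fold lower number from compound 2 to compound 3 (0.92 log units; beyond the scatter), though with little certainty about its size. Compound 3 is therefore estimated at 20000 nM, within a range from 3000 nM to 100000 nM.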

Compound 3, half-maximal inhibitory concentration: 6090 nM
Estimate against measurement, compound 3: 3.3-fold (0.52 log units) above; low and high end bracket the measured number.
By their numbers in this assay, from the lowest: compound 1; then compound 3; then compound 2.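

Replacing dimethylamino with methyl on this aromatic carbon gives a 28-fold lower number from compound 2 to compound 3 (1.44 log units; beyond the scatter) in this assay, so a change at this single position, with the nitrophenyl arm and the shared core left as they are, is enough to move the number far beyond the scatter. The group that leaves has 3 heavy atoms and 1 hydrogen-bond acceptor, while the methyl that enters has 1 heavy atom and 0 hydrogen-bond acceptors, and this one step cannot show which of these differences matters. No measurement shown here accounts for the size of the step.

Going by these compounds, whether a chlorine atom, an ethyl group or a primary amine at the same place would fall nearer to compound 3 or to compound 2 remains open. Also open, on these data alone, is whether the same swap would give a step of similar size with a different group on the second arm.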